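Moving the chlorines on the dichlorophenyl group

The compounds below may be only part of what the source reports. "The series", "measured", "known", "first", "only" and "open" are said of these compounds alone.

In a functional assay on SW-620 cells (Homo sapiens) for cytotoxicity, read by MTT assay, with a stated time of 72 h (a lower number here means a stronger inhibitor, a higher number a weaker inhibitor), compound 1 (`COc1ccc(/C=C2\CCC/C(=C\c3ccc(OC)c(OC)c3)C2=O)cc1`) gives 6600 nM and compound 2 (`COc1ccc(/C=C2\CCC/C(=C\c3cccc(Cl)c3Cl)C2=O)cc1OC`) gives 10800 nM as its value. Within the data shown here, these are the only two numbers so far, and they lie within the scatter of each other, so compound 2 stands level with compound 1.

Compound 3 (`COc1ccc(/C=C2\CCC/C(=C\c3cc(Cl)cc(Cl)c3)C2=O)cc1OC`) has not been measured. It differs from compound 2 only by 3,5-dichlorophenyl in place of 2,3-dichlorophenyl on a double-bonded chain carbon bound to a double-bonded ring carbon with the same atoms joined differently, and the swap sits on a double-bonded chain carbon bound to a double-bonded ring carbon.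

Among the measured compounds shown here, one measured step bears on this place: a 1.6-fold higher number from compound 1 to compound 2 (0.21 log units; within the scatter) when 2,3-dichlorophenyl replaces 4-methoxyphenyl, and that step stays within the scatter. For the measured compounds named here, no measured pair yet shows what moving the chlorines does, so the evidence is thin and the range must stay wide.

The estimate means a 1.2-fold lower number from compound 2 to compound 3 (0.08 log units; within the scatter) as the expected step in this assay and nothing beyond the scatter. Compound 3 is estimated at 9000 nM (expected range 3500 nM to 23000 nM).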

Compound 3, half-maximal inhibitory concentration: 2500 nM
Compound 3: the middle estimate sits 3.6-fold (0.56 log units) above what was measured; the whole stated range lies above it.
By their numbers in this assay, from the lowest: compound 3; then compounds 1 and 2 (each within the scatter of the next).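

In this assay, among these compounds, the first step beyond the scatter at this position comes from rearranging the chlorines alone (a 4.3-fold lower number from compound 2 to compound 3 (0.64 log units; beyond the scatter)), with 3,5-dichlorophenyl replacing 2,3-dichlorophenyl and the counts under comparison unchanged. The place on a double-bonded chain carbon bound to a double-bonded ring carbon therefore responds to how the same atoms are joined, not only to which kind of group stands there, and the replacement of 4-methoxyphenyl by 3,5-dichlorophenyl also passes the scatter (a 2.6-fold lower number from compound 1 to compound 3 (0.42 log units; beyond the scatter)), whereas the same replacement by 2,3-dichlorophenyl did not. Having two chlorines on the phenyl group is thus not enough to separate a compound from compound 1, and no measurement shown offers an explanation for the gap between the two chlorine arrangements.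

Still open, on these data alone, is whether the step belongs to the pair of chlorines or whether a single chlorine, or a trifluoromethyl group, would give a similar number at this place. Also open, as far as these compounds go, is how an amine or a carboxylic acid on the phenyl group would read in this assay and whether the chlorine effect carries over to other changes in the shared core.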